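A few compounds are considered here, and "the series" means these few. Any claim that something is new, unique, unknown or untested is made for them only; others in the source may bear on it.

Working notes on the series, all read in a functional assay on K562 cells (Homo sapiens) for antiproliferative activity, read by MTT assay, with a stated time of 72 h; on this read-out lower numbers stand for stronger inhibition and higher numbers for weaker inhibition. Compound 1 `COc1cc(-c2ncnn2-c2cccc(N)c2)cc(OC)c1OC` gives > 10000 nM, which is a limit of the assay and not a number. Within the data shown here, compound 2 `COc1ccc(-n2ncnc2-c2cc(OC)c(OC)c(OC)c2)cc1` gives 3600 nM, the only true number so far in this assay. Compound 3 `COc1cc(-c2ncnn2-c2ccc(Cl)c(Cl)c2)cc(OC)c1OC` keeps the shared core and has 3,4-dichlorophenyl in place of 4-methoxyphenyl on an aromatic nitrogen. Among the measured compounds shown here, one measured step bears on this place: an at least 2.7-fold lower number from compound 1 to compound 2 (0.44 log units; beyond the scatter). Its size is only a bound, as one end of it is the limit of > 10000 nM in this assay, at which 1 of the 2 values shown sits. It shows that the group on this nitrogen can move the number beyond the scatter, with 4-methoxyphenyl the better of the two groups so far. A shift of modest size towards weaker inhibition is therefore expected. The expected step is a 1.7-fold higher number from compound 2 to compound 3 (0.22 log units; within the scatter). For compound 3 the estimated value is 6000 nM, with an expected range from 1800 nM to 20000 nM.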

Compound 3, half-maximal inhibitory concentration: > 10000 nM
Compound 3: a limit, no number (the forecaster's own chance of this, stated with the estimate: 35%); at least 1.6-fold (0.22 log units) between middle value and limit.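

In this assay the change to 3,4-dichlorophenyl on this nitrogen gives an at least 2.7-fold higher number from compound 2 to compound 3 (0.44 log units; beyond the scatter). The value of compound 3 is a limit of the assay and not a number, so this size is only a bound. The single earlier step could not show that a second, different group also falls short of 4-methoxyphenyl, leaving compound 2 as the only compound with a readable number: the limit of > 10000 nM in this assay, at which 2 of the 3 values shown sit.

As far as these compounds go, the step between compound 1 and compound 3 cannot be read, so the order of 3-aminophenyl and 3,4-dichlorophenyl stays open. Also open, from the compounds shown here alone, is how an unsubstituted phenyl, 4-hydroxyphenyl or 4-ethoxyphenyl on this nitrogen would read, and so whether the methoxy group itself carries the difference.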